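Chlorophenyl for nitrophenyl on a cyano-acrylamide side chain

The compounds below may be only part of what the source reports. "The series", "measured", "known", "first", "only" and "open" are said of these compounds alone.

Compound 1 `C/C(=N\NC(=O)/C(C#N)=C/c1ccccc1)c1c(O)c2ccc(O)cc2oc1=O`: 15800 nM
Compound 2 `C/C(=N\NC(=O)/C(C#N)=C/c1ccc([N+](=O)[O-])cc1)c1c(O)c2ccc(O)cc2oc1=O`: 8360 nM

In a functional assay on HeLa cells (Homo sapiens) for cytotoxicity, read by MTT assay, with a stated time of 24 h (a lower number here means a stronger inhibitor, a higher number a weaker inhibitor), compound 2 gives 8360 nM, a value within the scatter of compound 1. Compound 3 `C/C(=N\NC(=O)/C(C#N)=C/c1ccccc1Cl)c1c(O)c2ccc(O)cc2oc1=O` has 2-chlorophenyl in place of 4-nitrophenyl on a double-bonded chain carbon bound to a double-bonded chain carbon. Within the data shown here, the only measured step that bears on this is a 1.9-fold lower number from compound 1 to compound 2 (0.28 log units; within the scatter), where nitro replaces hydrogen on an aromatic carbon. Among the measured compounds shown here, no measured compound carries chlorine, so the data give only weak guidance, and no shift beyond the scatter is expected. The estimated change is a 1.3-fold higher number from compound 2 to compound 3 (0.12 log units; within the scatter). Compound 3 is expected at 11000 nM, with an estimated range of 4500 nM to 28000 nM.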

Compound 3, half-maximal inhibitory concentration: 11800 nM
Compound 3: middle estimate off by 1.1-fold (0.03 log units), on the low side; measured number inside the range.
By their numbers in this assay, from the lowest: compounds 2, 3 and 1 (each within the scatter of the next).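

In this assay, 2-chlorophenyl in place of 4-nitrophenyl gives a 1.4-fold higher number from compound 2 to compound 3 (0.15 log units; within the scatter), and 2-chlorophenyl in place of phenyl gives a 1.3-fold lower number from compound 1 to compound 3 (0.13 log units; within the scatter). Phenyl, 4-nitrophenyl and 2-chlorophenyl on this double-bonded chain carbon therefore all stand within the scatter of one another, so neither added group has moved the number measurably. No measurement here offers a reason for this.

The compounds shown leave open whether 4-chlorophenyl would match 2-chlorophenyl, and whether an amine or a carboxylic acid on this phenyl ring would give a step beyond the scatter.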